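A Small Span Around Compound 3

The compounds below may be only part of what the source reports. "The series", "measured", "known", "first", "only" and "open" are said of these compounds alone.

Three compounds share one core and differ only in the aromatic group on a carbon with a double bond to nitrogen. In a functional assay on M14 cells (Homo sapiens) for inhibition, read by sulforhodamine B assay, with a stated time of 48 h (a lower number here means a stronger inhibitor of growth, a higher number a weaker inhibitor of growth), compound 1 (`O=C(Cc1csc2nc(-c3ccc(Br)cc3)cn12)N/N=C/c1ccccc1`) gives 20900 nM and compound 2 (`O=C(Cc1csc2nc(-c3ccc(Br)cc3)cn12)N/N=C/c1ccc(O)cc1`) gives 10200 nM in the same test. Compound 3 (`COc1cccc(OC)c1/C=N/NC(=O)Cc1csc2nc(-c3ccc(Br)cc3)cn12`) gives 15100 nM and so falls within the span of the other two. Its distance to each lies within the scatter, as seen in a 1.4-fold lower number from compound 1 to compound 3 (0.14 log units; within the scatter) and in a 1.5-fold higher number from compound 2 to compound 3 (0.17 log units; within the scatter) on either side. Within the data shown here, the only step beyond the scatter is modest, namely a 2.0-fold lower number from compound 1 to compound 2 (0.31 log units; beyond the scatter) with a single hydroxy in place of hydrogen on an aromatic carbon.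

Compound 4 (`O=C(Cc1csc2nc(-c3ccc(Br)cc3)cn12)N/N=C/c1ccc(Cl)cc1Cl`) changes the same place: 2,4-dichlorophenyl in place of 2,6-dimethoxyphenyl on a carbon with a double bond to nitrogen with 2,4-dichlorophenyl in place of 2,6-dimethoxyphenyl on a carbon with a double bond to nitrogen. Among the measured compounds shown here, no measured compound carries chlorine, so the evidence is indirect. All three measured changes at this place gave small steps, and none reached beyond a modest size. No step beyond the scatter is therefore expected, and the expected move is a 1.2-fold lower number from compound 3 to compound 4 (0.07 log units; within the scatter) in this estimate. Compound 4 is estimated at 13000 nM with an expected range from 6000 nM to 27000 nM in this assay when measured.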

Compound 4, concentration for 50% growth inhibition: 33100 nM
Compound 4: the middle estimate sits 2.5-fold (0.41 log units) below what was measured; the whole stated range lies below it.
By their numbers in this assay, from the lowest: compounds 2, 3, 1 and 4 (each within the scatter of the next, the first and the last beyond it).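

At this position in this assay, the move to 2,4-dichlorophenyl gives the first step from compound 3 that passes beyond the scatter, a 2.2-fold higher number from compound 3 to compound 4 (0.34 log units; beyond the scatter), so the place is less flat than the earlier trio suggested, though the step remains modest. The widest step yet seen at this place is a 3.2-fold higher number from compound 2 to compound 4 (0.51 log units; beyond the scatter), while a 1.6-fold higher number from compound 1 to compound 4 (0.20 log units; within the scatter) shows that the dichloro compound cannot be told apart from the plain phenyl compound, so the two chlorines give no clear separation from the unsubstituted ring, and only the hydroxy compound and the dimethoxy compound stand apart from compound 4. Nothing shown here offers an explanation for these differences.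

The two chlorines arrive together, so the compounds shown cannot say what either one contributes alone, and a single chlorine at either site would be needed to separate them. Going by these compounds, it also stays open whether an amine or a carboxylic acid on the ring, or a saturated ring or longer alkyl chain in place of the aromatic group, would move the number outside this narrow span.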